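A ring swap on compound 3, with no measured guide

The compounds below may be only part of what the source reports. "The series", "measured", "known", "first", "only" and "open" are said of these compounds alone.

Three compounds share one core, as drawn beside each. Compound 1 `COc1ccc(Nc2cc(Nc3ccc(Oc4ccncc4-c4cccnc4)c(F)c3)ncn2)cc1` has no result in a functional assay on MDA-MB-231 cells (Homo sapiens) for cytotoxicity, read by MTT assay, with a stated time of 72 h; on this read-out lower numbers stand for stronger inhibition and higher numbers for weaker inhibition: it stands as "not determined" (no result reported). Compound 2 `Fc1ccc(Nc2cc(Nc3ccc(Oc4ccncc4-c4cccnc4)c(F)c3)ncn2)cc1F` gives 6770 nM in this assay. Compound 3 `Cn1c(=O)c(C(=O)Nc2ccc(Oc3ccncc3-c3cccnc3)c(F)c2)nn(-c2ccc(Cl)cc2)c1=O` gives 3220 nM in this assay, the lowest of the two numbers, and the gap up to compound 2 lies beyond the usual scatter. Compound 4 `COc1ccc(-n2nc(C(=O)Nc3ccc(Oc4ccncc4-c4cccnc4)c(F)c3)c(=O)n(C)c2=O)c(OC)c1` differs from compound 3 in one place: 2,4-dimethoxyphenyl in place of 4-chlorophenyl on an aromatic nitrogen. For the measured compounds named here, no measured pair shows what such a change does here, so the size of the step is open. The step expected here is a 1.2-fold higher number from compound 3 to compound 4 (0.09 log units; within the scatter), with no clear direction beyond the scatter. Compound 4 is therefore estimated at 4000 nM, within a range from 1500 nM to 11000 nM.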

Compound 4, half-maximal inhibitory concentration: 3270 nM
The estimate for compound 4 lay 1.2-fold (0.09 log units) above the measured number; measured number inside the range.
By their numbers in this assay, from the lowest: compounds 3 and 4 (each within the scatter of the next); then compound 2.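

Swapping 4-chlorophenyl for 2,4-dimethoxyphenyl on the aromatic nitrogen gives a 1.0-fold higher number from compound 3 to compound 4 (0.01 log units; within the scatter) in this assay, so the two groups cannot be told apart here. The entering group is larger and carries hydrogen-bond acceptors that the leaving group lacks, yet the two numbers stay within the scatter of each other. Nothing available explains this result. Still open, as far as these compounds go, is whether a group of another kind at this position, such as a phenyl ring bearing an amine or a carboxylic acid, would move the number beyond the scatter.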